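This account rests on a few compounds, and the source may have more. Where it says the series, first, only, none or still open, it means among the compounds named here.

Of the compounds shown here, three with a shared core have been read in a toxicity assay on NIH3T3 cells (Mus musculus) for cytotoxicity, read by resazurin assay; on this read-out lower numbers stand for an effect already at smaller amounts and higher numbers for an effect only at larger amounts of compound. Compound 2 `c1ccc(-c2ccc(Cn3cncc3CNc3cccc(-c4ccccc4)c3)cc2)cc1` gives 10000 nM, a true number. Compound 1 `CN(C)c1ccc(NCc2cncn2Cc2ccc(-c3ccccc3)cc2)cc1-c1ccccc1` gives > 1000 nM, which is a limit. Compound 3 `CCOC(=O)c1ccc(NCc2cncn2Cc2ccc(-c3ccccc3)cc2)cc1-c1ccccc1` gives > 10000 nM, which is also a limit, so its place on the scale is known only from one side.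

Compound 4 `CCCC(=O)c1ccc(NCc2cncn2Cc2ccc(-c3ccccc3)cc2)cc1-c1ccccc1` changes compound 3 at a single spot: propyl in place of ethoxy on a carbonyl carbon. Put simply, ethoxycarbonyl becomes propylcarbonyl, with propyl in place of ethoxy on a carbonyl carbon.

The measured steps offer only weak guidance. Ethoxycarbonyl in place of hydrogen gives a number no lower from compound 2 to compound 3 (the limit leaves the size open). Ethoxycarbonyl in place of dimethylamino gives a step that the two limits leave unreadable from compound 1 to compound 3, and hydrogen in place of dimethylamino gives a step that the limit leaves unreadable from compound 1 to compound 2. None of these has a readable size, and none changes only the part beyond the carbonyl carbon. No step beyond the usual scatter, in either direction, can therefore be argued from them. The best anchor is compound 2 at 10000 nM. Compound 3 serves as a second anchor, and its > 10000 nM is a limit.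

The expected change is a step that the limit leaves unreadable from compound 3 to compound 4. Compound 4 is estimated at 12000 nM, with an expected range from 4000 nM to 30000 nM.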

Compound 4, half-maximal effective concentration: > 10000 nM
Compound 4 ended at the assay's limit (the forecaster's own chance of this, stated with the estimate: 60%); the middle value lies beyond the limit too.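

In this assay compound 4 gives > 10000 nM, which is a limit of the assay and not a number. Replacing ethoxy with propyl on the carbonyl carbon removes the oxygen of the ethoxy group, yet the read-out still does not fall to a true number, and compound 3 and compound 4 share one limit: the limit of > 10000 nM in this assay, at which 2 of the 4 values shown sit. The new propylcarbonyl compound also gives a number no lower from compound 2 to compound 4 (the limit leaves the size open), the same direction already seen for ethoxycarbonyl, while the other new steps cannot be read.

From the compounds shown here alone, how far compound 3 and compound 4 lie past the limit stays unknown, so neither the size nor the direction of the change between them can be told. Also open, going by these compounds, is whether a carboxylic acid at this position, an amine on the carbonyl carbon or a longer chain in place of propyl would give a true number in this assay.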